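From piperidin-1-yl to 4-propylpiperazin-1-yl in the series

The source may hold more compounds than are shown below. What is called first, only, known or untested is meant among the compounds shown, and "the series" means these compounds.

In a functional assay on MCF7 cells (Homo sapiens) for cytotoxicity, read by MTT assay, with a stated time of 72 h (on this read-out lower numbers stand for stronger inhibition and higher numbers for weaker inhibition), compound 3 `O=C1c2c[n+]([O-])c3ccccc3c2C(=O)c2c1c1ccccc1n2CCCCN1CCCCC1` gives 150 nM. Compound 1 `CN1CCN(CCCCn2c3c(c4ccccc42)C(=O)c2c[n+]([O-])c4ccccc4c2C3=O)CC1` gives 100 nM, and the gap is small: a 1.5-fold higher number from compound 1 to compound 3 (0.18 log units; within the scatter). Compound 2 `CCCCN1CCN(CCCCn2c3c(c4ccccc42)C(=O)c2c[n+]([O-])c4ccccc4c2C3=O)CC1` gives 6900 nM, far from that pair: a 46-fold lower number from compound 2 to compound 3 (1.66 log units; beyond the scatter).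

Compound 4 `CCCN1CCN(CCCCn2c3c(c4ccccc42)C(=O)c2c[n+]([O-])c4ccccc4c2C3=O)CC1` carries this change: 4-propylpiperazin-1-yl in place of piperidin-1-yl on a saturated chain carbon, four bonds along the chain from an aromatic nitrogen. The closest evidence is the large step with 4-methylpiperazin-1-yl and 4-butylpiperazin-1-yl: a 69-fold higher number from compound 1 to compound 2 (1.84 log units; beyond the scatter). Propyl is longer than the methyl and shorter than the butyl, so a rise beyond the scatter is expected in this assay, probably short of the value of compound 2. The expected size is a 13-fold higher number from compound 3 to compound 4 (1.12 log units; beyond the scatter). For compound 4 the estimate is 2000 nM, with an expected range of 400 nM to 7000 nM.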

Compound 4, half-maximal inhibitory concentration: 1280 nM
The estimate for compound 4 lay 1.6-fold (0.19 log units) above the measured number; low and high end bracket the measured number.
By their numbers in this assay, from the lowest: compounds 1 and 3 (each within the scatter of the next); then compound 4; then compound 2.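

In this assay the dependence on the 4-alkyl group now has a middle point: a 13-fold higher number from compound 1 to compound 4 (1.11 log units; beyond the scatter) for propyl against methyl, and a 5.4-fold lower number from compound 2 to compound 4 (0.73 log units; beyond the scatter) on going from butyl to propyl. The three 4-alkylpiperazin-1-yl compounds therefore run in chain order, with none of them against it. The step of an 8.5-fold higher number from compound 3 to compound 4 (0.93 log units; beyond the scatter) shows that 4-propylpiperazin-1-yl does not keep the level that 4-methylpiperazin-1-yl shares with piperidin-1-yl. Still open, going by these compounds, is where 4-ethylpiperazin-1-yl or an unsubstituted piperazin-1-yl would fall in this order. Nothing in the data shown accounts for the rise with chain length.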